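A few compounds are considered here, and "the series" means these few. Any claim that something is new, unique, unknown or untested is made for them only; others in the source may bear on it.

Of the compounds shown here, two in this set have been tested in an ADME assay on HEL cells (Homo sapiens) for cytotoxicity, with a stated time of 3 days; on this read-out lower numbers stand for higher toxicity in this test and higher numbers for lower toxicity in this test. Compound 1 `Cc1cc(-c2ccc(O)cc2)c2ncc(CSCCc3ccccc3)n2c1` gives 13.7 ug/mL in this assay, and compound 2 `Cc1cc(-c2cccs2)cn2c(CSCCc3ccccc3)cnc12` gives 32 ug/mL. Compound 2 therefore holds the higher of the two numbers, with compound 1 sitting below it by a gap wider than the usual scatter of repeats; the two structures differ in more than one place, so the gap alone does not single out one cause. Compound 3 `Cc1cc(-c2ccccc2O)cn2c(CSCCc3ccccc3)cnc12` has not yet been measured. It departs from compound 2 in a single way: 2-hydroxyphenyl in place of thiophen-2-yl on an aromatic carbon. Because compound 1 gives 13.7 ug/mL while also carrying a phenyl ring bearing a hydroxyl group, compound 3 is expected to sit a little below compound 2. The step of a 1.6-fold lower number from compound 2 to compound 3 (0.20 log units; within the scatter) is expected to be small, possibly within the scatter. For compound 3 the estimated value is 20 ug/mL, with a range from 8 ug/mL to 45 ug/mL.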

Compound 3, half-maximal cytotoxic concentration: > 50 ug/mL
Compound 3: only a limit was reported; the forecaster's own chance of this, stated with the estimate: 5%; middle value at least 2.5-fold (0.39 log units) away from the limit.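

In this assay, replacing thiophen-2-yl with 2-hydroxyphenyl on this aromatic carbon gives an at least 1.5-fold higher number from compound 2 to compound 3 (0.19 log units; that floor lies within the scatter). Compound 3 has only a limit of the assay, > 50 ug/mL, not an exact number, so the true size of this step cannot be read. Even so, this pair shows that at this position, meta to a methyl group, moving to a carbon-only six-membered ring bearing a hydroxyl group does not bring a lower number in this test.

The compounds shown leave open whether the hydroxyl group or the change of ring accounts for this step, which a plain phenyl or a 2-methoxyphenyl group on the same carbon would help to separate. They also leave open how an amine or a carboxylic acid on that ring would read in this assay.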